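Replacing Thiophen-3-yl with 4-Acetamidophenyl at the Amine

The source may hold more compounds than are shown below. What is called first, only, known or untested is meant among the compounds shown, and "the series" means these compounds.

Compound 3 `CN(Cc1ccsc1)C1CCN(CCCc2c[nH]c3ccc(-n4cnnc4)cc23)CC1` gives 1.5 nM in an assay on CHO cells for displacement of a labelled ligand from 5-hydroxytryptamine receptor 1D (Homo sapiens); on this read-out lower numbers stand for stronger inhibition and higher numbers for weaker inhibition. Compound 2 `CN(C1CCN(CCCc2c[nH]c3ccc(-n4cnnc4)cc23)CC1)S(=O)(=O)c1ccccc1` gives 1.5 nM in this assay, and there is no change at the digits printed from compound 2 to compound 3 (within the scatter). Compound 1 `O[C@H]1Cc2ccccc2C1NC1CCN(CCCc2c[nH]c3ccc(-n4cnnc4)cc23)CC1` gives 37 nM, with a 25-fold lower number from compound 1 to compound 3 (1.39 log units; beyond the scatter). Compound 3 therefore sits together with compound 2 at the lowest of the three numbers.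

Compound 4 `CC(=O)Nc1ccc(CN(C)C2CCN(CCCc3c[nH]c4ccc(-n5cnnc5)cc34)CC2)cc1` differs from compound 3 in one place: 4-acetamidophenyl in place of thiophen-3-yl on a saturated chain carbon bound to an amine nitrogen. Two of the known steps bear on this position. The step of no change at the digits printed from compound 2 to compound 3 (within the scatter) shows that exchanging one group for a quite different one on the amine nitrogen left the number where it was, while a 25-fold lower number from compound 1 to compound 2 (1.39 log units; beyond the scatter) and a 25-fold lower number from compound 1 to compound 3 (1.39 log units; beyond the scatter) show that only the indanyl-bearing amine of compound 1 stood apart. Within the data shown here, no measured step exchanges a thiophene for a substituted phenyl, so the expectation rests on the tolerance seen at this site. Compound 4 is expected to show a 1.3-fold higher number from compound 3 to compound 4 (0.12 log units; within the scatter), with an estimate of 2 nM and a range from 0.7 nM to 8 nM.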

Compound 4, half-maximal inhibitory concentration: 19 nM
Estimate against measurement, compound 4: 9.5-fold (0.98 log units) below, and the stated range ends below it.
By their numbers in this assay, from the lowest: compounds 2 and 3 (each within the scatter of the next); then compounds 4 and 1 (each within the scatter of the next).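

Exchanging thiophen-3-yl for 4-acetamidophenyl gave a 13-fold higher number from compound 3 to compound 4 (1.10 log units; beyond the scatter) in this assay, and exchanging phenylsulfonyl for 4-acetamidobenzyl gave a 13-fold higher number from compound 2 to compound 4 (1.10 log units; beyond the scatter). The level numbers of the two earlier groups on this amine nitrogen therefore did not extend to every group placed there, and 4-acetamidobenzyl is the first group on this methylated amine shown to raise the number beyond the scatter. Nothing available explains why this change raised the number.

The compounds shown do not separate the contribution of the six-membered aromatic ring from that of the acetamido group, which enters with it. An unsubstituted benzyl group would address that question, while an amine or a carboxylic acid in place of the acetamido group would show whether the step depends on that particular substituent.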